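Removing One Chloro From Compound 2

The source may report more compounds than this note shows. Statements on the series, on what has been measured and on what is new or still open speak of the compounds shown alone.

Measured so far in a physicochemical assay for solubility, measured as kinetic solubility; on this read-out lower numbers stand for lower solubility and higher numbers for higher solubility:

- compound 1 `C[C@H](NC(=O)c1cc(C(F)(F)F)ccc1Oc1ccccc1)c1cccc(S(C)(=O)=O)c1` gives 57000 nM
- compound 2 `O=C(N[C@@H](CO)c1cccc(Cl)c1)[C@H]1CC(F)(F)CC[C@@H]1c1ccccc1` gives 318000 nM
- compound 3 `CS(=O)(=O)c1cccc([C@H](CO)NC(=O)c2cc(C(F)(F)F)ccc2Oc2ccccc2)c1` gives 11000 nM

Compound 2 has the highest number of the three, clearly above both others. Compound 4 `O=C(N[C@@H](CO)c1ccccc1)[C@H]1CC(F)(F)CC[C@@H]1c1ccccc1` is compound 2 with a single change (hydrogen in place of chloro on an aromatic carbon): hydrogen in place of chloro on an aromatic carbon, meta to a large group.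

Among the compounds with values here, only one measured step exists to compare with (a 5.2-fold lower number from compound 1 to compound 3 (0.71 log units; beyond the scatter)). That step puts hydroxy in place of hydrogen on a saturated chain carbon, in compounds with a different core, so it is another kind of change. Within the data shown here, no measured pair shows what swapping chloro for hydrogen does here. Without such evidence, no step beyond the scatter is expected in this assay, and a firm direction cannot be given.

The step estimated here is small (a 1.3-fold higher number from compound 2 to compound 4 (0.10 log units; within the scatter)) and stays within the scatter. For compound 4 the estimated value is 400000 nM with an expected range from 180000 nM to 900000 nM in repeated measurements.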

Compound 4, solubility: 332000 nM
The estimate for compound 4 lay 1.2-fold (0.08 log units) above the measured number, and the stated range covers the measured number.
By their numbers in this assay, from the lowest: compound 3; then compound 1; then compounds 2 and 4 (each within the scatter of the next).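

In this assay, replacing 3-chlorophenyl with phenyl gives a 1.0-fold higher number from compound 2 to compound 4 (0.02 log units; within the scatter) and so stays within the usual scatter. Within the data shown here, this is the first measured pair for this swap, since the earlier compounds offered only a change on a saturated chain carbon in a different core. It shows that, on the core shared by compound 2 and compound 4, the chloro at this aromatic carbon can be exchanged for hydrogen without a step beyond the scatter on this read-out, and no measurement at hand explains this result.

As far as these compounds go, whether an amine, a carboxylic acid or a methoxy group at the same place would also leave the number within the scatter remains open. Also open, from the compounds shown here alone, is whether the same swap would behave alike on the core of compound 1 or compound 3.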